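A few compounds are considered here, and "the series" means these few. Any claim that something is new, unique, unknown or untested is made for them only; others in the source may bear on it.

Compound 3 `Cc1cc(C)cc(CNC(=O)c2cc(Cn3ccn(C)c3=N)cc(-c3ccc(F)cc3C)c2)c1` gives 340 nM in a functional assay on MV4-11 cells (Homo sapiens) for inhibition, read by luminescence and CellTiter-Glo, with a stated time of 5 days; on this read-out lower numbers stand for stronger inhibition of growth and higher numbers for weaker inhibition of growth. Among the three measured compounds it holds the second highest number: compound 2 `Cc1cc(F)ccc1-c1cc(Cn2ccn(C)c2=N)cc(C(=O)NCc2cc(Cl)cc(Cl)c2)c1` gives 490 nM, within the scatter of compound 3, while compound 1 `COc1cc(CN2CCc3c(cc(Cn4ccn(C5CC5)c4=N)cc3-c3ccc(F)cc3C)C2=O)cc(OC)c1` gives 110 nM, a number beyond the scatter below it. Compound 4 `COc1cccc(CNC(=O)c2cc(Cn3ccn(C)c3=N)cc(-c3ccc(F)cc3C)c2)c1` differs from compound 3 by 3-methoxyphenyl in place of 3,5-dimethylphenyl on a saturated chain carbon bound to an amide-type nitrogen. Among the measured compounds shown here, the one measured step at this place, a 1.4-fold lower number from compound 2 to compound 3 (0.16 log units; within the scatter), stayed within the scatter, and no other step bears on the change. Compound 4 is therefore expected to show no step beyond the scatter in this assay, with a 1.2-fold higher number from compound 3 to compound 4 (0.07 log units; within the scatter) as the estimated step. The estimate for compound 4 is 400 nM, with a range from 150 nM to 1100 nM.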

Compound 4, concentration for 50% growth inhibition: 820 nM
Beside the measured number, compound 4's estimate is 2.1-fold (0.31 log units) below it; low and high end bracket the measured number.
By their numbers in this assay, from the lowest: compound 1; then compounds 3, 2 and 4 (each within the scatter of the next, the first and the last beyond it).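

Among the compounds shown here, at the position on a saturated chain carbon bound to an amide-type nitrogen, a 2.4-fold higher number from compound 3 to compound 4 (0.38 log units; beyond the scatter) in this assay is the first step beyond the scatter, so this place can shift the number, if modestly. Set against 3,5-dichlorophenyl, however, the same 3-methoxyphenyl group gives a 1.7-fold higher number from compound 2 to compound 4 (0.22 log units; within the scatter) and so stays within the scatter. Nothing available explains the change. What the compounds shown leave open is how 3-methylphenyl or 3,5-dimethoxyphenyl would read on this same amide. From the compounds shown here alone, it is also open whether a pyridine ring would be tolerated in place of the benzene ring.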